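The source may hold more compounds than are shown below. What is called first, only, known or untested is meant among the compounds shown, and "the series" means these compounds.

The measured compounds:
Compound 1 `COc1ccccc1/C=C1\CCC/C(=C\c2cccc(OC)c2OC)C1=O` gives > 20000 nM in a functional assay on SW-620 cells (Homo sapiens) for cytotoxicity, read by MTT assay, with a stated time of 72 h (a higher number here means a weaker inhibitor, a lower number a stronger inhibitor), which is a limit of the assay.
Compound 2 `COc1ccc(/C=C2\CCC/C(=C\c3cccc(OC)c3OC)C2=O)c(OC)c1` gives > 20000 nM in this assay, again a limit of the assay.
Compound 3 `COc1cccc(/C=C2\CCC/C(=C\c3cc(OC)c(OC)c(OC)c3)C2=O)c1OC` gives 2500 nM in this assay.

Compound 1 therefore stands at a limit and not at a number, and it shares that position with one further compound; (the limit of > 20000 nM in this assay, at which 2 of the 3 values shown sit). Compound 4 `COc1cccc(/C=C2\CCC/C(=C\c3ccc(O)c(O)c3)C2=O)c1OC` differs from compound 1 in one place: 3,4-dihydroxyphenyl in place of 2-methoxyphenyl on a double-bonded chain carbon bound to a double-bonded ring carbon. For the measured compounds named here, only one measured step bears on a change to that ring, namely a step that the two limits leave unreadable from compound 1 to compound 2, and it is unreadable since both ends sit at the limit. Going by the values given here, compound 3 is the one measured compound that gives a number rather than a limit, and it shows that a ring change on this side of the shared core can reach a measurable value. Compound 4 is thus expected to move out of the limit, with the step from compound 1 to compound 4 estimated at an at least 6.6-fold lower number from compound 1 to compound 4 (0.82 log units; beyond the scatter), though its size against a limit cannot be fixed. Compound 4 is estimated at 3000 nM, with a range from 800 nM to 20000 nM.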

Compound 4, half-maximal inhibitory concentration: 6300 nM
Estimate against measurement, compound 4: 2.1-fold (0.32 log units) below, within the range that was stated.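

In this assay, the change to 3,4-dihydroxyphenyl gives an at least 3.1-fold lower number from compound 1 to compound 4 (0.50 log units; beyond the scatter). For the compounds shown here, this is the first readable step at this position, as the earlier methoxy step on this ring cannot be read. Compound 4 shows that the ring at this place need not carry any methoxy group for a number to be read, since its 3,4-dihydroxyphenyl holds two hydroxyl groups instead. The step remains only a lower bound because compound 1 sits at a limit of the assay: the limit of > 20000 nM in this assay, at which 2 of the 4 values shown sit.

From the compounds shown here alone, whether both hydroxyl groups are needed for this step remains open, as does how a ring with a single hydroxyl group would read. The compounds shown also leave open how an amine or a carboxylic acid on this ring would read in this assay.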